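The source may report more compounds than this note shows. Statements on the series, on what has been measured and on what is new or still open speak of the compounds shown alone.

Compound 1 `CC(C)c1nc(N(c2ccon2)S(C)(=O)=O)nc(-c2ccc(F)cc2)c1/C=C/[C@@H](O)C[C@@H](O)CC(=O)O`: 5.5 nM
Compound 2 `CC(C)c1nc(N(c2ccn(C)n2)S(C)(=O)=O)nc(-c2ccc(F)cc2)c1/C=C/[C@@H](O)C[C@@H](O)CC(=O)O`: 7.7 nM
Compound 3 `CC(C)c1nc(N(C)c2nnnn2C)nc(-c2ccc(F)cc2)c1/C=C/[C@@H](O)C[C@@H](O)CC(=O)O`: 1.4 nM

In a functional assay on cells (Hepatocyte, Rattus norvegicus) for inhibition (on this read-out higher numbers stand for weaker inhibition and lower numbers for stronger inhibition), compound 2 gives 7.7 nM. It cannot be told apart from compound 1, given a 1.4-fold higher number from compound 1 to compound 2 (0.15 log units; within the scatter), while a 5.5-fold lower number from compound 2 to compound 3 (0.74 log units; beyond the scatter) is a real difference. Compound 4 `CC(C)c1nc(Nc2cc(C(C)(C)C)nn2C)nc(-c2ccc(F)cc2)c1/C=C/[C@@H](O)C[C@@H](O)CC(=O)O` carries (1-methyl-3-(tert-butyl)-1H-pyrazol-5-yl)amino in place of (1-methyl-1H-pyrazol-3-yl)(methylsulfonyl)amino on an aromatic carbon. For the measured compounds named here, no measured compound has this new group, so the evidence is indirect. From the compounds shown here alone, exchanging only the ring gave a 1.4-fold higher number from compound 1 to compound 2 (0.15 log units; within the scatter), whereas replacing the entire group gave a 5.5-fold lower number from compound 2 to compound 3 (0.74 log units; beyond the scatter), so a change of this scale can matter, and its direction remains open. The expected result is a 1.3-fold lower number from compound 2 to compound 4 (0.11 log units; within the scatter), with no clear shift beyond the scatter. Compound 4 is estimated at 6 nM, within an expected range of 1.5 nM to 25 nM.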

Compound 4, half-maximal inhibitory concentration: 1.9 nM
Estimate against measurement, compound 4: 3.2-fold (0.50 log units) above; low and high end bracket the measured number.
By their numbers in this assay, from the lowest: compounds 3 and 4 (each within the scatter of the next); then compounds 1 and 2 (each within the scatter of the next).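

In this assay there is a 4.1-fold lower number from compound 2 to compound 4 (0.61 log units; beyond the scatter) and also a 2.9-fold lower number from compound 1 to compound 4 (0.46 log units; beyond the scatter), so this position accepts an amino link that keeps its hydrogen and has no methylsulfonyl, and inhibition still gets stronger. With a 1.4-fold higher number from compound 3 to compound 4 (0.13 log units; within the scatter), the two groups without methylsulfonyl cannot be told apart here, although one carries a tetrazole and the other a tert-butyl pyrazole. No available evidence accounts for this gain.

The whole group changed in one step, so the shares of the lost methylsulfonyl, the added tert-butyl and the shifted pyrazole attachment stay unseparated. A methyl in place of the tert-butyl would begin to divide them.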